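The source may report more compounds than this note shows. Statements on the series, on what has been measured and on what is new or still open speak of the compounds shown alone.

Measured so far in this series:
compound 1 `Cn1c(NN)nc(-c2cccc(O)c2O)c(C#N)c1=O` — 31 ug/mL
compound 2 `CCOC(=O)c1cnn(-c2nc(-c3cccs3)c(C#N)c(=O)n2C)c1N` — 97 ug/mL
compound 3 `Cn1c(NN)nc(-c2ccccc2O)c(C#N)c1=O` — 34 ug/mL

In a functional assay on microsomes for inhibition, with a stated time of 1 h (on this read-out higher numbers stand for weaker inhibition and lower numbers for stronger inhibition), compound 2 stands highest of the three numbers; compound 3 is nearest and compound 1 furthest, both separated from compound 2 by more than the scatter. Compound 4 `CCOC(=O)c1cnn(-c2nc(-c3ccco3)c(C#N)c(=O)n2C)c1N` differs from compound 2 by furan-2-yl in place of thiophen-2-yl on an aromatic carbon. Among the compounds with values here, the one measured step, a 1.1-fold higher number from compound 1 to compound 3 (0.04 log units; within the scatter), concerns a hydroxy group elsewhere on the shared core and does not bear on this exchange; no measured pair swaps thiophen-2-yl for furan-2-yl. With nothing to support a direction, the expected step of no change at the digits printed from compound 2 to compound 4 (within the scatter) is taken as none beyond the scatter. Compound 4 is therefore estimated at 97 ug/mL, with a range from 48 ug/mL to 195 ug/mL.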

Compound 4, half-maximal inhibitory concentration: 116 ug/mL
For compound 4 the middle estimate is 1.2-fold (0.08 log units) below the measured one; the measured number falls inside the stated range.
By their numbers in this assay, from the lowest: compounds 1 and 3 (each within the scatter of the next); then compounds 2 and 4 (each within the scatter of the next).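

In this assay, within the data shown here, the step of a 1.2-fold higher number from compound 2 to compound 4 (0.08 log units; within the scatter) is the first measured exchange at this aromatic carbon, ortho to a cyano group. Among these compounds, replacing thiophen-2-yl with furan-2-yl, one five-membered aromatic ring for another, leaves the read-out within the scatter, with sulfur giving way to oxygen as the only change of atom. No measurement in hand accounts for this result.

On these data alone, how an amine or a carboxylic acid would read at this position remains open. So does whether the same exchange reads alike on the core of compound 3.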